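Furyl-to-pyridyl swap on two related pyridine cores

This account rests on a few compounds, and the source may have more. Where it says the series, first, only, none or still open, it means among the compounds named here.

Measured compounds:
- compound 1, `Oc1ccc(-c2cc(-c3ccco3)nc(-c3ccccc3Cl)c2)cc1`: 3.9%
- compound 2, `Oc1ccc(-c2cc(-c3ccncc3)nc(-c3ccccc3Cl)c2)cc1`: 9.9%
- compound 3, `Oc1cccc(-c2cc(-c3ccc(Cl)cc3)nc(-c3ccco3)c2)c1`: 27.1%

In an assay on isolated protein for inhibition of DNA topoisomerase 1 (Homo sapiens), with a stated time of 30 min, tested at 100 uM (a higher number here means a stronger effect of the compound at the concentration tested, a lower number a weaker effect), compound 1 gives 3.9% and compound 2 gives 9.9%. The step between them is a number 6 percentage points higher from compound 1 to compound 2 (within the scatter), the change being (pyridin-4-yl in place of furan-2-yl on an aromatic carbon). Compound 3 has the same atoms as compound 1 joined differently; the difference between the two cores is not broken down here. In this assay compound 3 gives 27.1%, the highest of the three numbers, beyond the scatter from both compound 1 and compound 2.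

Compound 4, `Oc1cccc(-c2cc(-c3ccncc3)nc(-c3ccc(Cl)cc3)c2)c1`, has not been measured. It differs from compound 3 by pyridin-4-yl in place of furan-2-yl on an aromatic carbon. This is the same kind of change as that from compound 1 to compound 2, but not the same: on the core of compound 1 the place is meta to a 2-chlorophenyl group and meta to a 4-hydroxyphenyl group, whereas on the core of compound 3 it is meta to a 3-hydroxyphenyl group and meta to a 4-chlorophenyl group. The change occurs twice among the compounds shown, once measured.

For compound 4 the expected step in this assay is a number 4.9 percentage points higher from compound 3 to compound 4 (within the scatter), resting on the measured step of a number 6 percentage points higher from compound 1 to compound 2 (within the scatter), which lay within the scatter. Going by the values given here, the estimate for compound 4 is therefore 32%, expected between 14% and 50%, since only one example of the change is known and it sits on a different core.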

Compound 4, a percentage reported as inhibition, at one concentration (the size of the read-out at that concentration, not a potency): 8%
Compound 4: middle estimate off by 24 percentage points, on the high side; the measured number lies below the stated range.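

In this assay, pyridin-4-yl in place of furan-2-yl on the second core gives a number 19.1 percentage points lower from compound 3 to compound 4 (beyond the scatter), so the swap lowers the read-out there, whereas the earlier step on the other core gave no change that stands clear of the scatter. The outcome of this change therefore cannot be carried from one core to the other as a fixed step in this series: the same change on two cores in this assay, a number 6 percentage points higher (within the scatter) from compound 1 to compound 2 and a number 19.1 percentage points lower (beyond the scatter) from compound 3 to compound 4, 25.1 percentage points apart, beyond the scatter of two such steps. This does not show which difference between the cores matters, since the 4-hydroxyphenyl and 2-chlorophenyl groups of one core and the 3-hydroxyphenyl and 4-chlorophenyl groups of the other vary together, and two pairs of compounds, each read at a single concentration, give no general rule and no cause.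

Still open, going by these compounds, is whether the 3-hydroxyphenyl group or the 4-chlorophenyl group governs the step, which a core pairing 3-hydroxyphenyl with 2-chlorophenyl, carrying furan-2-yl and then pyridin-4-yl, could separate. Also open, on these data alone, is how other groups at the same place would read out in this assay, for example thiophen-2-yl, pyridin-3-yl or a saturated cyclic amine such as piperidin-4-yl.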